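The compounds below may be only part of what the source reports. "The series", "measured", "known", "first", "only" and "open" are said of these compounds alone.

Compound 1 `CC(C)CCCOc1cccc(O)c1C(=O)/C=C/c1ccc(O)cc1` carries an isopentyl chain on the shared core; in a functional assay on HCT-15 cells (Homo sapiens) for antiproliferative activity, read by sulforhodamine B assay (a higher number here means a weaker inhibitor of growth, a lower number a stronger inhibitor of growth), compound 1 gives 11600 nM, the higher of the two numbers recorded. Compound 2 `CC(C)(C)CCOc1cccc(O)c1C(=O)/C=C/c1ccc(O)cc1` gives 3430 nM, a change of a 3.4-fold lower number from compound 1 to compound 2 (0.53 log units; beyond the scatter). Compound 3 `CCCCOc1cccc(O)c1C(=O)/C=C/c1ccc(O)cc1` reaches only the assay limit, > 30000 nM. The steps of an at least 2.5-fold higher number from compound 1 to compound 3 (0.41 log units; beyond the scatter) and an at least 8.7-fold higher number from compound 2 to compound 3 (0.94 log units; beyond the scatter) are both bounded by the limit of > 30000 nM in this assay, at which 1 of the 3 values shown sits. Compound 4 `CCC(CC)COc1cccc(O)c1C(=O)/C=C/c1ccc(O)cc1` differs from compound 1 in one place: pentan-3-yl in place of isopentyl on a saturated chain carbon bound to an oxygen on an aromatic ring. Branching gave a modest gain in a 3.4-fold lower number from compound 1 to compound 2 (0.53 log units; beyond the scatter), while shortening cost in an at least 2.5-fold higher number from compound 1 to compound 3 (0.41 log units; beyond the scatter); compound 4 keeps the chain length and gains branching, so a small gain is expected. Compound 4 is therefore expected to give 7000 nM, within 2500 nM to 20000 nM. The expected step is a 1.7-fold lower number from compound 1 to compound 4 (0.22 log units; within the scatter).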

Compound 4, concentration for 50% growth inhibition: 3420 nM
Compound 4: middle estimate off by 2.0-fold (0.31 log units), on the high side; measured number inside the range.
By their numbers in this assay, from the lowest: compounds 4 and 2 (each within the scatter of the next); then compound 1. At a limit, above all of these: compound 3.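

Pentan-3-yl in place of isopentyl on a saturated chain carbon bound to an oxygen on an aromatic ring gives a 3.4-fold lower number from compound 1 to compound 4 (0.53 log units; beyond the scatter) in this assay, so the same atoms joined differently alter the result. Compound 4 and compound 2 cannot be told apart, with a 1.0-fold lower number from compound 2 to compound 4 (0.00 log units; within the scatter). The step of an at least 8.7-fold lower number from compound 3 to compound 4 (0.94 log units; beyond the scatter) is only a bound, as compound 3 stands at a limit: the limit of > 30000 nM in this assay, at which 1 of the 4 values shown sits.

Going by these compounds, whether a longer branched chain, a cyclohexylmethyl group or an amine at this position would go beyond compound 2 and compound 4 stays open.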